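Methoxy for cyclopropyl on the fused ring of compound 3

The source may report more compounds than this note shows. Statements on the series, on what has been measured and on what is new or still open speak of the compounds shown alone.

Three compounds share one core and one amide linkage. Compound 1 `Cc1c(C(=O)Nc2ccc(Oc3ncnc4[nH]cc(-c5ccccc5)c34)c(F)c2)c(=O)c2cc(Cl)ccc2n1C` gives 1890 nM in an assay on isolated protein for inhibition of tyrosine-protein kinase receptor UFO (Homo sapiens), read by FRET and Z'-LYTE, with a stated time of 1.5 h; a lower number here means a stronger inhibitor, a higher number a weaker inhibitor. Compound 2 `CCCCn1c(C)c(C(=O)Nc2ccc(Oc3ncnc4[nH]cc(-c5ccccc5)c34)c(F)c2)c(=O)c2cc(C)ccc21` gives 480 nM in this assay. Compound 3 `Cc1c(C(=O)Nc2ccc(Oc3ncnc4[nH]cc(-c5ccccc5)c34)c(F)c2)c(=O)c2cc(C3CC3)ccc2n1C` gives 230 nM in this assay, the lowest of the three numbers. Among the compounds with values here, the only single-place step measured so far is an 8.2-fold lower number from compound 1 to compound 3 (0.91 log units; beyond the scatter). Compound 4 `COc1ccc2c(c1)c(=O)c(C(=O)Nc1ccc(Oc3ncnc4[nH]cc(-c5ccccc5)c34)c(F)c1)c(C)n2C` is not yet measured; it differs from compound 3 by methoxy in place of cyclopropyl on an aromatic carbon. Within the data shown here, no measured step exchanges cyclopropyl for methoxy, so the one step that bears on it, an 8.2-fold lower number from compound 1 to compound 3 (0.91 log units; beyond the scatter), shows only that the group at this place matters. The expected outcome for compound 4 is a modest step toward a higher number, a 2.2-fold higher number from compound 3 to compound 4 (0.34 log units; beyond the scatter), with wide uncertainty. Compound 4 is therefore estimated at 500 nM, within 150 nM to 1600 nM.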

Compound 4, half-maximal inhibitory concentration: 99 nM
Compound 4: the middle estimate sits 5.1-fold (0.70 log units) above what was measured, outside the stated range (below it).
By their numbers in this assay, from the lowest: compound 4; then compound 3; then compound 2; then compound 1.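

Methoxy on this aromatic carbon gives a 2.3-fold lower number from compound 3 to compound 4 (0.37 log units; beyond the scatter) in this assay, so a three-membered ring is not required here for the lowest number in the series. Starting from chloro, the same group gives a 19-fold lower number from compound 1 to compound 4 (1.28 log units; beyond the scatter), the widest span among the three groups compared at this place. No evidence on hand explains this order of methoxy, cyclopropyl and chloro.

The compounds shown leave open how ethoxy, a longer alkoxy chain or an amine would rank at this place against methoxy.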